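This account rests on a few compounds, and the source may have more. Where it says the series, first, only, none or still open, it means among the compounds named here.

Measured so far:
Compound 1 `O=C(c1sc(-c2cccc(F)c2)nc1O)N1CCOC1`: 5500 nM in an assay on HEK293 cells for inhibition of transient receptor potential cation channel subfamily M member 8 (Homo sapiens), read by FLIPR, with stated times of 5 min and 3 min; on this read-out higher numbers stand for weaker inhibition and lower numbers for stronger inhibition.
Compound 2 `CCNC(=O)c1sc(-c2ccccc2)nc1O`: > 100000 nM, a limit of this assay.
Compound 3 `CCOC(=O)c1oc(-c2ccc(Cl)cc2)nc1O`: > 100000 nM, a limit of this assay.

Among the measured compounds shown here, compound 1 holds the only actual number in this assay; the other two values are the limit of > 100000 nM in this assay, at which 2 of the 3 values shown sit. For the measured compounds named here, no pair of measured compounds differs in one place only, so nothing in the set yet tells how far a single change moves this assay.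

Compound 4 `CON(C)C(=O)c1sc(-c2cccc(F)c2)nc1O` differs from compound 1 at the carbonyl: a group of 4 heavy atoms (2 carbon, 1 nitrogen, 1 oxygen; no ring) in place of a group of 5 heavy atoms (3 carbon, 1 nitrogen, 1 oxygen; one five-membered non-aromatic ring with 2 hetero atoms), on a carbonyl carbon. Both groups are tertiary amides of similar size, and the rest of the structure is unchanged. Compound 2 with its secondary amide and compound 3 with its ester each sit at a limit, but each differs from compound 1 in more than one place, so neither bears directly on this step. The step from compound 1 to compound 4 is expected to be a 1.5-fold higher number from compound 1 to compound 4 (0.16 log units; within the scatter), small, close to the usual scatter, with no direction that can be claimed from the data. Compound 4 is therefore expected to give about 8000 nM, with a range from 2500 nM to 30000 nM.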

Compound 4, half-maximal inhibitory concentration: 96 nM
The estimate for compound 4 lay 83-fold (1.92 log units) above the measured number; the measured number lies below the stated range.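

On a carbonyl carbon, methoxy(methyl)amino in place of the five-membered non-aromatic ring with 2 hetero atoms gives a 57-fold lower number from compound 1 to compound 4 (1.76 log units; beyond the scatter) in this assay. Among the compounds shown here, this is the first single-place comparison, and it marks the group on the carbonyl as a place where one change among tertiary amides can move the number well beyond the scatter. The leaving and entering groups have the same counts of hydrogen-bond donors and acceptors and neither carries a net charge, so these counted features do not separate them, and nothing measured here accounts for the size of the step.

The compounds shown do not tell whether the step depends on the oxygen attached to the amide nitrogen, the open chain, or both; a dimethylamino group and a methoxyamino group on the same carbonyl would separate these possibilities. Also open, going by these compounds, is whether methoxy(methyl)amino gives a similar step on a core with chlorine in place of the fluorine, or with an unsubstituted phenyl group.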